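A Second Nitrophenyl Swap: What to Expect for Compound 4

The source may report more compounds than this note shows. Statements on the series, on what has been measured and on what is new or still open speak of the compounds shown alone.

Compound 1, `CN(C(=O)NC(=O)c1cccc(C(F)(F)F)c1)c1nc(C(F)(F)F)c(C(=O)N/N=C/c2cccc(C(F)(F)F)c2)s1`, gives 5.79 ug/mL in a functional assay on HepG2 cells (Homo sapiens) for inhibition, read by MTT assay, with a stated time of 72 h; on this read-out lower numbers stand for stronger inhibition and higher numbers for weaker inhibition.
Compound 2, `CN(C(=O)NC(=O)c1ccc([N+](=O)[O-])cc1)c1nc(C(F)(F)F)c(C(=O)N/N=C/c2cccc(C(F)(F)F)c2)s1`, gives 4.73 ug/mL in this assay.
Compound 3, `CN(C(=O)NC(=O)c1ccccc1F)c1nc(C(F)(F)F)c(C(=O)N/N=C/c2ccccc2C(F)(F)F)s1`, gives 5.39 ug/mL in this assay.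

Among these three numbers compound 2 has the lowest, but its gaps to compound 3 and to compound 1 are both within the scatter of this assay, so the three compounds cannot be told apart on these data.

Compound 4, `CN(C(=O)NC(=O)c1ccc([N+](=O)[O-])cc1)c1nc(C(F)(F)F)c(C(=O)N/N=C/c2ccc([N+](=O)[O-])cc2)s1`, is not yet measured. It differs from compound 2 in one place: 4-nitrophenyl in place of 3-(trifluoromethyl)phenyl on a carbon with a double bond to nitrogen. Within the data shown here, the one measured step that speaks to this is the same exchange made on a carbonyl carbon, which gave a 1.2-fold lower number from compound 1 to compound 2 (0.09 log units; within the scatter). If that exchange behaves alike on the carbon with a double bond to nitrogen, compound 4 should stay close to compound 2 in this assay, with no step beyond the scatter expected in either direction. Among the measured compounds shown here, the change here, however, sits on the side of the molecule that no measured pair has varied, so the expectation carries a wider range.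

Compound 4 is therefore estimated at 4.8 ug/mL in this assay, within a range of 2.4 ug/mL to 9.6 ug/mL, which means an expected step of a 1.0-fold higher number from compound 2 to compound 4 (0.01 log units; within the scatter).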

Compound 4, half-maximal inhibitory concentration: 12.3 ug/mL
Compound 4: the middle estimate sits 2.6-fold (0.41 log units) below what was measured; the whole stated range lies below it.
By their numbers in this assay, from the lowest: compounds 2, 3 and 1 (each within the scatter of the next); then compound 4.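

In this assay the exchange of 3-(trifluoromethyl)phenyl for 4-nitrophenyl on a carbon with a double bond to nitrogen gave a 2.6-fold higher number from compound 2 to compound 4 (0.42 log units; beyond the scatter), the only step shown that lies beyond the scatter. The same exchange on a carbonyl carbon gave a 1.2-fold lower number from compound 1 to compound 2 (0.09 log units; within the scatter), so the earlier compounds had shown no sensitivity to this swap, while the carbon with a double bond to nitrogen does respond to it, and the reading from one place cannot be carried over to the other. Nothing in the data shown accounts for this difference between the two places.

On these data alone, it remains open whether the higher number comes with the departure of 3-(trifluoromethyl)phenyl or with the arrival of 4-nitrophenyl, since a single exchange cannot separate the two, and an unsubstituted phenyl or a phenyl carrying an amine on the carbon with a double bond to nitrogen would help to tell them apart. As far as these compounds go, it is also open whether the step keeps its size when the carbonyl carbon carries a group other than 4-nitrophenyl, such as 3-(trifluoromethyl)phenyl.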